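Dropping the methyl from compound 3

The source may report more compounds than this note shows. Statements on the series, on what has been measured and on what is new or still open speak of the compounds shown alone.

Measured in a functional assay on Hs 683 cells (Homo sapiens) for cytotoxicity, read by MTT assay, with a stated time of 72 h; on this read-out higher numbers stand for weaker inhibition and lower numbers for stronger inhibition:
- compound 1 `c1ccc2[nH]c(-n3cccn3)cc2c1`: > 100000 nM (a limit)
- compound 2 `COc1ccc2[nH]c3c4cn[nH]c4c4c(c3c2c1)C(=O)NC4=O`: 45000 nM
- compound 3 `Cc1ccc2[nH]c3c4cn[nH]c4c4c(c3c2c1)C(=O)NC4=O`: > 100000 nM (a limit)

Compound 3 is known only as a limit, > 100000 nM. That value is the limit of > 100000 nM in this assay, at which 2 of the 3 values shown sit. Compound 4 `O=C1NC(=O)c2c1c1[nH]ncc1c1[nH]c3ccccc3c21` has hydrogen in place of methyl on an aromatic carbon. Among the compounds with values here, the one measured step at this carbon is an at least 2.2-fold higher number from compound 2 to compound 3 (0.34 log units; beyond the scatter), and it rests on a limit. The removal of a methyl is a small change, so no step beyond the scatter is expected in this assay, although a limit is again a likely result. The expected step is an at least 1.2-fold lower number from compound 3 to compound 4 (0.09 log units; that floor lies within the scatter). Compound 4 is expected at 80000 nM, with an estimated range from 30000 nM to 150000 nM.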

Compound 4, half-maximal inhibitory concentration: 93000 nM
The estimate for compound 4 lay 1.2-fold (0.07 log units) below the measured number; the range from low to high includes it.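

In this assay, hydrogen in place of methoxy on this carbon gives a 2.1-fold higher number from compound 2 to compound 4 (0.32 log units; beyond the scatter), so the gain with methoxy, earlier seen only against a limit, now stands against a measured number. Hydrogen in place of methyl gives an at least 1.0-fold lower number from compound 3 to compound 4 (0.03 log units; that floor lies within the scatter), and that step cannot be sized because its starting value is only a limit: the limit of > 100000 nM in this assay, at which 2 of the 4 values shown sit.

Still open, as far as these compounds go, is whether a hydroxyl, an amine or a longer chain such as ethoxy on this carbon would move the number further than methoxy does.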